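The source may report more compounds than this note shows. Statements on the series, on what has been measured and on what is new or still open speak of the compounds shown alone.

Notes on the series. The shared core is common to compound 1 `CC(=O)Oc1ccc(C(=O)Nc2cc3ccc(OCC4CCCNC4)c(C)c3oc2=O)cc1CC=C(C)C` and compound 2 `CCN(CC)CCCOc1ccc2cc(NC(=O)c3ccc(O)c(CC=C(C)C)c3)c(=O)oc2c1C`. In a functional assay on SK-BR-3 cells (Homo sapiens) for antiproliferative activity (on this read-out lower numbers stand for stronger inhibition and higher numbers for weaker inhibition), compound 1 gives 620 nM, and in this assay compound 2 gives 4900 nM. Of the two numbers recorded so far, compound 2 carries the higher one, and the gap to compound 1 lies beyond the scatter of this assay. For the measured compounds named here, no step between two measured compounds that differ in a single place is available, so the next change is taken without a direct precedent.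

Compound 3 `CC(C)=CCc1cc(C(=O)Nc2cc3ccc(OCCCNCC(N)=O)c(C)c3oc2=O)ccc1O` is the next compound, not yet measured in this assay. Relative to compound 2 the change is (carbamoylmethyl)amino in place of diethylamino on a saturated chain carbon, three bonds along the chain from an oxygen on an aromatic ring. Nothing measured here speaks to the direction of this change, so for compound 3 the step of a 1.2-fold lower number from compound 2 to compound 3 (0.09 log units; within the scatter) is expected to stay within the scatter, with the range kept wide. Compound 3 is therefore estimated at 4000 nM, between 1200 nM and 13000 nM.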

Compound 3, half-maximal inhibitory concentration: 2290 nM
Compound 3: the middle estimate sits 1.7-fold (0.24 log units) above what was measured; low and high end bracket the measured number.
By their numbers in this assay, from the lowest: compound 1; then compound 3; then compound 2.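

Notes on the chain end. In this assay, for the compounds shown here, (carbamoylmethyl)amino in place of diethylamino gives a 2.1-fold lower number from compound 2 to compound 3 (0.33 log units; beyond the scatter), a modest step, and this is the first direct reading at this position on the chain. The change does not cost activity here: the entering group brings hydrogen-bond donors and a double bond outside aromatic rings, where diethylamino has neither, and the number still falls. Nothing available accounts for the size or direction of this step.

The compounds shown leave open whether the step follows from the carbamoylmethyl part of the entering group or simply from the loss of the ethyl groups. A plain primary amine or a carboxylic acid on the same saturated chain carbon would bear on that, and a longer chain would show how much the distance from the ring oxygen matters.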